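This account rests on a few compounds, and the source may have more. Where it says the series, first, only, none or still open, it means among the compounds named here.

Measured so far:
- compound 1 `O=c1c2ccccc2c(Cc2ccc(Cl)cc2)nn1CCNCCCCc1ccc(OCCCN2CCCCCC2)cc1`; in an assay for binding affinity to Alpha-1B adrenergic receptor (Homo sapiens) (on this read-out higher numbers stand for weaker inhibition and lower numbers for stronger inhibition), compound 1 gives 316 nM
- compound 2 `CN1CCC[C@@H]1Cn1nc(CC2CCCCC2)c2ccccc2c1=O`; in this assay compound 2 shows only a limit, > 1990 nM

For compound 2 the value in this assay is a limit and not a number; this is the limit of > 1990 nM in this assay, at which 1 of the 2 values shown sits. Compound 1 carries a different side chain on the shared core, so its value and that of compound 2 are simply read side by side.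

Compound 3 `CN1CCC[C@@H]1Cn1nc(Cc2cccc(F)c2)c2ccccc2c1=O` differs from compound 2 in one place: 3-fluorophenyl in place of cyclohexyl on a saturated chain carbon bound to an aromatic carbon. With no measured step of this kind in the set, the expected step from compound 2 to compound 3 is a step that the limit leaves unreadable from compound 2 to compound 3, most likely none beyond the scatter. Compound 3 is expected to give about 2500 nM, within 600 nM to 10000 nM, with a fair chance that only a limit is reported.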

Compound 3, inhibition constant: 398 nM
The estimate for compound 3 lay 6.3-fold (0.80 log units) above the measured number, outside the stated range (below it).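

In this assay the series shows an at least 5.0-fold lower number from compound 2 to compound 3 (0.69 log units; beyond the scatter) with 3-fluorophenyl in place of cyclohexyl on a saturated chain carbon bound to an aromatic carbon. This position therefore responds to the ring it carries, which compound 1 and compound 2 alone could not show. The full size of the step stays unreadable, since compound 2 has only a limit and not a number: the limit of > 1990 nM in this assay, at which 1 of the 3 values shown sits.

From the compounds shown here alone, whether the step belongs to the aromatic ring or to its fluorine remains open. An unsubstituted phenyl at this place would separate the two, and a pyridyl ring would test the ring further.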